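Trimming the aromatic tail of a cyanoguanidine histamine antagonist

The source may report more compounds than this note shows. Statements on the series, on what has been measured and on what is new or still open speak of the compounds shown alone.

Compound 1 `N#C/N=C(\NCCCCc1ccccc1)NCCCCc1c[nH]cn1` gives 5.03 in an in vitro functional assay on Sf9 cells for antagonist activity at histamine H2 receptor (Homo sapiens); on this read-out higher numbers stand for higher potency (the scale is a negative logarithm) and lower numbers for lower potency.
Compound 2 `N#C/N=C(/NCCCCc1c[nH]cn1)NCCCc1ccncc1` gives 5.11 in this assay.

Compound 2 and compound 1 sit within the scatter of each other, so the two numbers cannot be told apart. Compound 3 `CCN/C(=N\C#N)NCCCCc1c[nH]cn1` differs from compound 2 by hydrogen in place of (pyridin-4-yl)methyl on a saturated chain carbon, two bonds along the chain from an amine nitrogen. For the measured compounds named here, the only measured step, a number 0.08 log units higher from compound 1 to compound 2 (within the scatter), exchanged one aromatic ring for another and left the number essentially unchanged, whereas here the ring is removed altogether, a change no measured pair covers. Compound 3 is therefore expected to lose some potency in this assay, with a step of about a number 0.51 log units lower from compound 2 to compound 3 (beyond the scatter). Compound 3 is estimated at 4.6, within a range from 4 to 5.2.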

Compound 3, negative logarithm of the antagonist equilibrium constant: < 5
Compound 3 ended at the assay's limit; the forecaster's own chance of this, stated with the estimate: 15%; the middle value lies beyond the limit too.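

Compound 3 gives a limit, not a number, in this assay: the limit of < 5 in this assay, at which 1 of the 3 values shown sits.

Putting hydrogen in place of the ring-bearing tail, on a saturated chain carbon two bonds along the chain from an amine nitrogen, gives a number at least 0.11 log units lower from compound 2 to compound 3 (that floor lies within the scatter) and a number at least 0.03 log units lower from compound 1 to compound 3 (that floor lies within the scatter). Unlike the earlier swap of one ring for another, this change removes the ring altogether, and it brings no gain in potency.

On these data alone, how far the potency of compound 3 really falls stays open. Also open, as far as these compounds go, is whether a plain butyl chain or a cyclohexyl group on the same nitrogen would read like the aromatic tails.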